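Swapping Bromo for Nitro on the Shared Core

The source may hold more compounds than are shown below. What is called first, only, known or untested is meant among the compounds shown, and "the series" means these compounds.

Of the compounds shown here, three sharing one core have been measured in a functional assay on PC-3 cells (Homo sapiens) for cytotoxicity, read by MTT assay, with a stated time of 48 h; a lower number here means a stronger inhibitor, a higher number a weaker inhibitor. Compound 1 `CC(C)n1c(/C=C2/C(=O)Nc3ccccc32)nc2ccccc21` gives 37600 nM. Compound 2 `CCn1c(/C=C2/C(=O)Nc3ccc(Br)cc32)nc2ccccc21` gives 42700 nM, and compound 3 `CC(C)n1c(/C=C2/C(=O)Nc3ccc(F)cc32)nc2ccccc21` gives 20800 nM. Within the data shown here, of the three numbers, the one for compound 2 is the highest, but its gap to compound 1 lies within the usual scatter, so the two cannot be told apart; only its gap to compound 3 lies beyond the scatter.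

The next compound, compound 4 `CCn1c(/C=C2/C(=O)Nc3ccc([N+](=O)[O-])cc32)nc2ccccc21`, differs from compound 2 in one place: nitro in place of bromo on an aromatic carbon. Among the measured compounds shown here, no measured step replaces a bromo with a nitro, so nothing bears on this change directly. For the measured compounds named here, the only single-point step available, a 1.8-fold lower number from compound 1 to compound 3 (0.26 log units; within the scatter), shows that a small change on the same six-membered ring moved the number by an amount within the scatter, and compound 2 and compound 1 differ at two places yet sit close together. On that basis no step beyond the scatter is expected in this assay for compound 4, in either direction; the estimate is a 1.2-fold lower number from compound 2 to compound 4 (0.09 log units; within the scatter). Compound 4 is therefore expected to give about 35000 nM, with a range from 15000 nM to 80000 nM.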

Compound 4, half-maximal inhibitory concentration: 40100 nM
For compound 4 the middle estimate is 1.1-fold (0.06 log units) below the measured one; low and high end bracket the measured number.
By their numbers in this assay, from the lowest: compounds 3, 1, 4 and 2 (each within the scatter of the next, the first and the last beyond it).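

Putting nitro in place of bromo on this aromatic carbon gives a 1.1-fold lower number from compound 2 to compound 4 (0.03 log units; within the scatter) in this assay, and this is the only direct reading of the swap among the compounds shown. The change is not a trivial one on paper: one heavy atom leaves and three enter, and a group with no hydrogen-bond acceptors gives way to one with two, yet compound 2 and compound 4 cannot be told apart in this assay, so at this position on the six-membered aromatic ring the difference between these two groups does not register in the read-out. No measurement is available that could account for this match.

Still open, from the compounds shown here alone, is whether any group on this same carbon can move the number beyond the usual scatter, for example an amine or a carboxylic acid, both of which differ in kind from bromo and nitro. The result also covers only this one carbon, so a nitro group placed elsewhere on the ring remains an open question.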